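Second chloro on the fused core: compound 2 to compound 4

The source may report more compounds than this note shows. Statements on the series, on what has been measured and on what is new or still open speak of the compounds shown alone.

Measured so far:
Compound 1 `ClCc1cccc(Cn2cnc3c(Cl)ncnc32)c1` — 30200 nM
Compound 2 `ClCc1ccccc1Cn1cnc2ncnc(Cl)c21` — 6020 nM
Compound 3 `ClCc1cccc(Cn2cnc3nc(Cl)nc(Cl)c32)c1` — 1730 nM

The three compounds were tested in a functional assay on BT-549 cells (Homo sapiens) for cytotoxicity, read by sulforhodamine B assay, with a stated time of 48 h; a lower number here means a stronger inhibitor of growth, a higher number a weaker inhibitor of growth. Compound 2 stands second highest of the three numbers; compound 3 gives the lowest, and the difference between the two lies beyond the scatter, as does the larger difference between compound 2 and compound 1, which gives the highest number.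

Compound 4 `ClCc1ccccc1Cn1cnc2nc(Cl)nc(Cl)c21` has not been measured in this assay. It differs from compound 2 in one place: chloro in place of hydrogen on an aromatic carbon. Among the compounds with values here, no step between two measured compounds follows exactly this change, so any expectation rests on what the two values of compound 1 and compound 3 show. Compound 3 carries two chloro groups on its core and gives a much lower number than compound 1, which carries one; this is an indication only, and the two compounds differ elsewhere as well.

On that basis a step beyond the scatter toward a lower number is expected for compound 4, of the size a 4.0-fold lower number from compound 2 to compound 4 (0.60 log units; beyond the scatter). Compound 4 is estimated at 1500 nM, within a range from 500 nM to 5000 nM.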

Compound 4, concentration for total growth inhibition: 3090 nM
Beside the measured number, compound 4's estimate is 2.1-fold (0.31 log units) below it; the measured number falls inside the stated range.
By their numbers in this assay, from the lowest: compounds 3, 4 and 2 (each within the scatter of the next, the first and the last beyond it); then compound 1.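

In this assay, chloro in place of hydrogen on the aromatic carbon between two ring nitrogen atoms gives a 1.9-fold lower number from compound 2 to compound 4 (0.29 log units; within the scatter), so in this pair the added chloro produces no difference that can be told from the usual scatter of repeated measurements. Within the data shown here, this is the first view of the change on its own, as the earlier compounds with one and two chloro groups on the core also differ elsewhere. At this position and in this pair, then, the added chloro alone does not give a step beyond the scatter. Nothing available bears on why the step has this size.

The compounds shown leave open whether another group at this same place, such as an amine or a methoxy group, would give a step beyond the scatter from compound 2. They also leave open how much the chloromethyl group contributes to these numbers, which a plain methyl or a hydroxymethyl group in its place would address.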